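One Methoxy Shift, Two Cores, One Expectation

The source may report more compounds than this note shows. Statements on the series, on what has been measured and on what is new or still open speak of the compounds shown alone.

Compound 1 `COc1ccc(/C=C/C(=O)c2ccc(OCCn3cc(CN4C(=O)/C=C/C(C)(C)C/C=C(\C)CC/C=C/4C)nn3)cc2O)cc1`: 2.85 ug/mL
Compound 2 `COc1cccc(/C=C/C(=O)c2ccc(OCCn3cc(CN4C(=O)/C=C/C(C)(C)C/C=C(\C)CC/C=C/4C)nn3)cc2O)c1`: 1.12 ug/mL
Compound 3 `COc1ccc(/C=C/C(=O)c2ccc(OCCCN3C(=O)/C=C/C(C)(C)C/C=C(\C)CC/C=C/3C)cc2)cc1`: 3.17 ug/mL

Of the compounds shown here, three have been measured in a functional assay on MCF7 cells (Homo sapiens) for antiproliferative activity; a lower number here means a stronger inhibitor, a higher number a weaker inhibitor. Compound 1 and compound 2 share one core, and compound 2 differs from compound 1 by 3-methoxyphenyl in place of 4-methoxyphenyl on a double-bonded chain carbon bound to a double-bonded chain carbon. That change produced a 2.5-fold lower number from compound 1 to compound 2 (0.41 log units; beyond the scatter). Compound 3 has a different core; how its core differs from that of compound 1 is not broken down here. In this assay compound 3 gives 3.17 ug/mL, which lies within the scatter of the number for compound 1, while compound 2 gives a lower number than either.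

Compound 4 `COc1cccc(/C=C/C(=O)c2ccc(OCCCN3C(=O)/C=C/C(C)(C)C/C=C(\C)CC/C=C/3C)cc2)c1` has not yet been measured. It differs from compound 3 by 3-methoxyphenyl in place of 4-methoxyphenyl on a double-bonded chain carbon bound to a double-bonded chain carbon, and the place of the change reads the same as for the pair of compound 1 and compound 2, so this is the same change made on the other core. Among the compounds shown it occurs two times in all, once measured and once not.

Because the same change gave a 2.5-fold lower number from compound 1 to compound 2 (0.41 log units; beyond the scatter), compound 4 is expected to show a step of similar direction on the core of compound 3, estimated as a 2.1-fold lower number from compound 3 to compound 4 (0.32 log units; beyond the scatter). For the measured compounds named here, the step is estimated a little smaller than the measured one, since the two cores differ and only one measured pair carries this change. Compound 4 is therefore expected to give about 1.5 ug/mL in this assay, with a likely range from 0.7 ug/mL to 3.2 ug/mL.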

Compound 4, half-maximal inhibitory concentration: 1.37 ug/mL
Compound 4: middle estimate off by 1.1-fold (0.04 log units), on the high side; low and high end bracket the measured number.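

On the second core, 3-methoxyphenyl in place of 4-methoxyphenyl gave a 2.3-fold lower number from compound 3 to compound 4 (0.36 log units; beyond the scatter) in this assay, the same direction as on the first core. Set side by side, the two steps show no difference in size beyond what repeated measurements would allow: the same change on two cores in this assay, a 2.5-fold lower number (0.41 log units; beyond the scatter) from compound 1 to compound 2 and a 2.3-fold lower number (0.36 log units; beyond the scatter) from compound 3 to compound 4, 1.1-fold (0.04 log units) apart, within the scatter of two such steps. For the compounds shown here, this shows that, in these two pairs, the change carried from one core to the other with its direction and size kept, but it rests on only two pairs in this assay, so it sets no rule for other cores and does not explain why the 3-methoxyphenyl compounds give the lower numbers.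

The compounds shown leave open whether the step depends on the methoxy group itself, since no compound here carries an ethoxy group, a chlorine or a plain phenyl in its place. They also leave open whether the step would hold on a core with a longer chain, or on one bearing an amine or a carboxylic acid, where the same exchange of 4-methoxyphenyl for 3-methoxyphenyl might give a step of another size.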